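Working notes: loss of trifluoromethyl from compound 1

The compounds below may be only part of what the source reports. "The series", "measured", "known", "first", "only" and "open" are said of these compounds alone.

Among the measured compounds shown here, compound 1 `C=CCc1cc(-c2ccccc2C(F)(F)F)ccc1O` is the only member of this set with a number in a functional assay on A549 cells (Homo sapiens) for antiproliferative activity, read by MTT assay, with a stated time of 24 h; on this read-out lower numbers stand for stronger inhibition and higher numbers for weaker inhibition: compound 1 gives 59700 nM. Compound 2 `C=CCOc1ccc(-c2ccc(OC)cc2)cc1CC=C` gives only a limit, > 100000 nM, in this assay. Compound 3 `C=CCc1cc(-c2cccc([N+](=O)[O-])c2)ccc1OC` likewise gives only a limit, > 100000 nM. For the measured compounds named here, two of the three values therefore sit at the limit of > 100000 nM in this assay, at which 2 of the 3 values shown sit, so compound 1 stands as the one compound with a measurable, though weak, antiproliferative read-out.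

Compound 4 `C=CCc1cc(-c2ccccc2)ccc1O` is not yet measured. It differs from compound 1 by hydrogen in place of trifluoromethyl on an aromatic carbon, on an aromatic carbon of a six-membered aromatic ring of carbon only, ortho to a large group. Going by the values given here, no step between measured compounds exists in this set, so nothing here calibrates such a change. The expectation is a step of modest size, toward weaker inhibition, with a fair chance that it does not exceed the scatter; the estimated step of a 1.4-fold higher number from compound 1 to compound 4 (0.15 log units; within the scatter) reflects this. Compound 4 is estimated at 85000 nM, within a range from 35000 nM to 200000 nM, and a reading that is only a limit would not be surprising.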

Compound 4, half-maximal inhibitory concentration: > 100000 nM
Compound 4 gave a limit, no number; the forecaster's own chance of this, stated with the estimate: 40%; middle value at least 1.1-fold (0.07 log units) from the limit.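

Hydrogen in place of trifluoromethyl on an aromatic carbon, ortho to a large group, supplies the first step that can be read in this set: the change gives an at least 1.6-fold higher number from compound 1 to compound 4 (0.22 log units; that floor lies within the scatter) in this assay and is the only comparison between compounds differing in one place. As far as these compounds go, only a floor is available for this step, so a real loss on removing trifluoromethyl is neither established nor excluded, and the full size of the step stays unknown. Among the compounds shown here, compound 4 has a limit and not a number, so compound 1 remains the only compound with a number: (the limit of > 100000 nM in this assay, at which 3 of the 4 values shown sit).

From the compounds shown here alone, how a methyl group, a chlorine atom or an amine at this position would read stays open. The compounds shown also leave open whether trifluoromethyl behaves the same way on a core with the hydroxyl group replaced by a methoxy group.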